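The source may hold more compounds than are shown below. What is called first, only, known or untested is meant among the compounds shown, and "the series" means these compounds.

In a functional assay on MDA-MB-435 cells (Homo sapiens) for antiproliferative activity, read by sulforhodamine B assay, with a stated time of 72 h (on this read-out lower numbers stand for stronger inhibition and higher numbers for weaker inhibition), compound 1 `C(=C/c1ccccc1)\C(=N\Nc1nncc2ccccc12)c1ccccc1` gives 3 nM, the lower of the two numbers available, while compound 2 `S=C(NNc1nncc2ccccc12)Nc1ccccc1` gives 74 nM. Compound 3 `Clc1ccc(C(/C=C/c2ccccc2)=N\Nc2nncc3ccccc23)cc1` has not yet been measured. It differs from compound 1 by chloro in place of hydrogen on an aromatic carbon, turning a phenyl into a 4-chlorophenyl: chloro in place of hydrogen on an aromatic carbon. For the measured compounds named here, no measured pair shows this kind of change, so the expectation in this assay is only a small move toward a higher number, possibly none beyond the scatter. The expected change is a 1.7-fold higher number from compound 1 to compound 3 (0.22 log units; within the scatter). Compound 3 is estimated at 5 nM, with an expected range of 1.5 nM to 20 nM.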

Compound 3, half-maximal inhibitory concentration: 5.6 nM
For compound 3 the middle estimate is 1.1-fold (0.05 log units) below the measured one; the range from low to high includes it.
By their numbers in this assay, from the lowest: compounds 1 and 3 (each within the scatter of the next); then compound 2.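

In this assay, chloro in place of hydrogen on an aromatic carbon, para to a large group, gives a 1.9-fold higher number from compound 1 to compound 3 (0.27 log units; within the scatter). Turning this phenyl into a 4-chlorophenyl thus leaves the number within the scatter, so this position accepts a single chlorine atom without a measurable loss, which the earlier compounds could not show. No measured evidence bears on this result. The compounds shown leave open whether an amine, a methoxy group or a carboxylic acid would be accepted at this same position, and whether chloro would be accepted on the other phenyl ring.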